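Ester-side truncation in the glycosylated series

This account rests on a few compounds, and the source may have more. Where it says the series, first, only, none or still open, it means among the compounds named here.

Among the compounds with values here, compound 1, `C/C=C1/[C@H](O[C@@H]2O[C@H](CO)[C@@H](O)[C@H](O)[C@H]2O)OC=C(C(=O)OC)[C@H]1CC(=O)OCCc1ccc(O)c(O)c1`, is the only member of the set with a number in a functional assay on SK-BR-3 cells (Homo sapiens) for antiproliferative activity, read by MTT assay, with a stated time of 72 h; on this read-out lower numbers stand for stronger inhibition and higher numbers for weaker inhibition: compound 1 gives 160000 nM. Compound 2, `C/C=C1/[C@H](O[C@@H]2O[C@H](CO)[C@@H](O)[C@H](O)[C@H]2O)OC=C(C(=O)OC)[C@H]1CC(=O)OCCc1ccc(O)cc1`, carries hydrogen in place of hydroxy on an aromatic carbon. In this assay compound 2 reaches only a limit, > 20000 nM. Compound 3, `C/C=C1/[C@H](O[C@@H]2O[C@H](CO)[C@@H](O)[C@H](O)[C@H]2O)OC=C(C(=O)OC)[C@H]1CC(=O)OCC`, has hydrogen in place of 3,4-dihydroxyphenyl on a saturated chain carbon, two bonds along the chain from an oxygen next to a carbonyl group, relative to compound 1. For compound 3 this assay likewise reports only a limit, > 15000 nM. The measured steps are all unreadable, a step that the limit leaves unreadable from compound 1 to compound 2, a step that the limit leaves unreadable from compound 1 to compound 3 and a step that the two limits leave unreadable from compound 2 to compound 3, because the limit of > 15000 nM in this assay, at which 1 of the 3 values shown sits, and the limit of > 20000 nM in this assay, at which 1 of the 3 values shown sits, cap the weaker side. Compound 3 thus stands at a limit with no number of its own.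

Compound 4, `C/C=C1/[C@H](O[C@@H]2O[C@H](CO)[C@@H](O)[C@H](O)[C@H]2O)OC=C(C(=O)OC)[C@H]1CC(=O)OC`, differs from compound 3 by hydrogen in place of methyl on a saturated chain carbon bound to an oxygen next to a carbonyl group. Within the data shown here, none of the measured steps touches this place, so they give no direction for the change. Compound 3 already sits at a limit, so no readable step beyond the scatter is expected. Compound 4 is expected to give 50000 nM, between 15000 nM and 200000 nM, most likely again as a limit. This corresponds to an expected step that the limit leaves unreadable from compound 3 to compound 4.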

Compound 4, half-maximal inhibitory concentration: > 15000 nM
Compound 4 gave a limit, no number; the forecaster's own chance of this, stated with the estimate: 80%; the middle value does not contradict the limit.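

Compound 4 reaches only a limit, > 15000 nM, in this assay. Its steps to compound 1, compound 2 and compound 3 therefore cannot be read, because the values stop at a limit: the limit of > 15000 nM in this assay, at which 2 of the 4 values shown sit.

From the compounds shown here alone, how compound 2, compound 3 and compound 4 rank against compound 1 or one another in this assay stays open.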